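A few compounds are considered here, and "the series" means these few. Any claim that something is new, unique, unknown or untested is made for them only; others in the source may bear on it.

Four close relatives of one shared core, each pairing two fused sulfur-containing ring systems through a single amine bridge, were tested in a functional assay on B16-F10 cells (Mus musculus) for cytotoxicity, read by MTT assay, with a stated time of 48 h; on this read-out higher numbers stand for weaker inhibition and lower numbers for stronger inhibition. Compound 1, `Clc1cccc2sc(Nc3nc4ccccc4s3)nc12`, gives 29500 nM. Compound 2, `Fc1ccc2nc(Nc3nc4ccccc4s3)sc2c1`, reaches only the limit of the assay, recorded as > 50000 nM; > 50000 nM (2 entries), and this is a limit rather than a number. Compound 3, `Clc1ccc2nc(Nc3nc4ccccc4s3)sc2c1`, likewise stops at the limit of the assay, > 50000 nM, so no single number is known for it. Its standing among the values shown is therefore set by the limit of > 50000 nM in this assay, at which 1 of the 3 values shown sits: one of the three values rests at that limit, and compound 3 sits on it rather than above or below a measured figure.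

The next compound, compound 4, `c1ccc2sc(Nc3nc4ccccc4s3)nc2c1`, differs from compound 3 in one place: hydrogen in place of chloro on an aromatic carbon. Among the measured compounds shown here, no step between measured compounds is recorded for this change, so only the weak showing of compound 3 and the measured value of compound 1 guide the expectation. Compound 4 is expected to remain weak, near 40000 nM, within a range from 15000 nM to 50000 nM. That would amount to an expected change of an at least 1.2-fold lower number from compound 3 to compound 4 (0.09 log units; that floor lies within the scatter), which is not beyond the usual scatter.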

Compound 4, half-maximal inhibitory concentration: > 50000 nM
Compound 4 ended at the assay's limit; the forecaster's own chance of this, stated with the estimate: 45%; at least 1.2-fold (0.09 log units) between middle value and limit.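

In this assay compound 4, with hydrogen in place of chloro on an aromatic carbon, gives > 50000 nM as a limit of the assay and not a number. Removing the chloro from this position therefore brings no measurable activity into view, and the step between compound 3 and compound 4 cannot be read because both values are limits. Among the compounds shown here, compound 1 carries its chloro at a different place, and the only readable step, an at least 1.6-fold higher number from compound 1 to compound 4 (0.22 log units; that floor lies within the scatter) and so not separable from ordinary scatter, leaves the limit as the main feature of this small set: the limit of > 50000 nM in this assay, at which 2 of the 4 values shown sit.

From the compounds shown here alone, how far compound 3 and compound 4 lie beyond that limit remains open. Also open, going by these compounds, is whether an amine or a methoxy group at this position would give a measurable number in this assay and how it would compare with chloro.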